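The source may report more compounds than this note shows. Statements on the series, on what has been measured and on what is new or still open speak of the compounds shown alone.

Compound 1 `CCn1ccnc1-c1cc(OC)c(OC)c(OC)c1` carries a trimethoxyphenyl group on a small five-membered core and an ethyl group on one of the ring nitrogens. In a functional assay on MDA-MB-231 cells (Homo sapiens) for antiproliferative activity, read by MTT assay, with a stated time of 72 h (a lower number here means a stronger inhibitor, a higher number a weaker inhibitor), compound 1 gives > 100000 nM, which is a limit of the assay and not a measured number. A second compound, compound 2 `COc1cc(-c2nccn2S(=O)(=O)c2ccc(C)cc2)cc(OC)c1OC`, keeps the same core and trimethoxyphenyl group but bears a tosyl group on the ring nitrogen. In this assay compound 2 gives > 100000 nM, again a limit rather than a number. So compound 1 stands at the limit of > 100000 nM in this assay, at which 2 of the 2 values shown sit, and nothing among the known values separates it from compound 2. The compound still to be tested, compound 3 `COc1cccc(-n2ccnc2-c2cc(OC)c(OC)c(OC)c2)c1`, differs from compound 1 in one place: 3-methoxyphenyl in place of ethyl on an aromatic nitrogen. Among the measured compounds shown here, no step between measured compounds is available to anchor the size of this change, and the known values give only limits. The expected step from compound 1 to compound 3 in this assay is an at least 5.0-fold lower number from compound 1 to compound 3 (0.69 log units; beyond the scatter), toward stronger inhibition, though with little confidence that it clears the scatter. For compound 3 the estimate in this assay is 20000 nM, with a range from 2000 nM to 100000 nM.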

Compound 3, half-maximal inhibitory concentration: 18300 nM
Compound 3: the middle estimate sits 1.1-fold (0.04 log units) above what was measured; low and high end bracket the measured number.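

In this assay compound 3 gives 18300 nM, the first real number among the compounds shown, so the group on this aromatic nitrogen can bring a compound within the range where the assay gives a number. Putting 3-methoxyphenyl in place of ethyl at that nitrogen gives an at least 5.4-fold lower number from compound 1 to compound 3 (0.73 log units; beyond the scatter), and this size is only a lower bound, as compound 1 sits at a limit of the assay and not at a measured number. Only compound 3 has moved off the limit that holds the other two compounds, the ethyl compound and the tosyl compound: the limit of > 100000 nM in this assay, at which 2 of the 3 values shown sit.

The change brings in both an aromatic ring and a methoxy group, and the compounds shown cannot separate the two, which a plain phenyl group on the same nitrogen could begin to do. Also open, going by these compounds, is whether a different group on that ring, such as an amine or a carboxylic acid, or a benzyl group on the nitrogen, would move the number further toward stronger inhibition or back to the limit.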